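Exchanging Iodine for Piperidine on the Sulfonamide Ring

A few compounds are considered here, and "the series" means these few. Any claim that something is new, unique, unknown or untested is made for them only; others in the source may bear on it.

Of the compounds shown here, two have been measured so far. Compound 1 `CC(C(=O)NCc1ccc(C(C)(C)C)cc1)c1ccc(NS(C)(=O)=O)cc1` in an assay on CHO cells for displacement of a labelled ligand from transient receptor potential cation channel subfamily V member 1 (Rattus norvegicus), read by scintillation counting, with a stated time of 60 min (a lower number here means a stronger inhibitor, a higher number a weaker inhibitor), gives 106 nM. Compound 2 `CC(C(=O)NCc1ccc(C(C)(C)C)cc1)c1ccc(NS(C)(=O)=O)c(I)c1` differs from it only by an iodine; in this assay compound 2 gives 23.3 nM. Among the compounds with values here, the single step between measured compounds, a 4.5-fold lower number from compound 1 to compound 2 (0.66 log units; beyond the scatter), shows that iodo in place of hydrogen on an aromatic carbon brought a clearly lower number. Compound 2 therefore stands lowest of the two values, with compound 1 above it by that step.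

Compound 3 `CC(C(=O)NCc1ccc(C(C)(C)C)cc1)c1ccc(NS(C)(=O)=O)c(N2CCCCC2)c1` is not yet measured. It differs from compound 2 by piperidin-1-yl in place of iodo on an aromatic carbon, so the iodine gives way to a six-membered non-aromatic ring holding one nitrogen, on an aromatic carbon. Within the data shown here, no measured step bears directly on this exchange. The step of a 4.5-fold lower number from compound 1 to compound 2 (0.66 log units; beyond the scatter) says only that filling that carbon with iodine lowered the number; it says nothing about a larger ring there. The expectation for compound 3 in this assay is therefore a number close to that of compound 2, with a wide range, and the estimated step is a 1.7-fold higher number from compound 2 to compound 3 (0.23 log units; within the scatter). Compound 3 is estimated at 40 nM, between 10 nM and 160 nM.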

Compound 3, inhibition constant: "active" (no number reported)
Compound 3 has no reported number here; no gap can be computed for the estimate.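

In this assay, within the data shown here, compound 3 is reported only as active, with no number given, so no step between compound 2 and compound 3 can be read. No other data here bear on this result. Still open, as far as these compounds go, is whether piperidin-1-yl in place of iodo gives a higher number, a lower one, or about the same.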